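A Longer Chain on the 4-Chlorophenyl Compound

The compounds below may be only part of what the source reports. "The series", "measured", "known", "first", "only" and "open" are said of these compounds alone.

In a functional assay on K562 cells (Homo sapiens) for inhibition, read by fluorescence, with a stated time of 72 h (a lower number here means a stronger inhibitor of growth, a higher number a weaker inhibitor of growth), compound 1 `COc1ccc(Nc2nc(N[C@H]3CC[C@H](N)CC3)nc3c2ncn3CCC(C)C)c(OC)c1` gives 5500 nM, while compound 2 `CC(C)CCn1cnc2c(Nc3ccc(Cl)cc3)nc(N[C@H]3CC[C@H](N)CC3)nc21` gives 1800 nM, the lower of the two numbers. Compound 3 `CCCCCCn1cnc2c(Nc3ccc(Cl)cc3)nc(N[C@H]3CC[C@H](N)CC3)nc21` differs from compound 2 in its chain: butyl in place of isopropyl on a saturated chain carbon, two bonds along the chain from an aromatic nitrogen. For the measured compounds named here, the only measured step, a 3.1-fold lower number from compound 1 to compound 2 (0.49 log units; beyond the scatter), is a different change, 4-chlorophenyl in place of 2,4-dimethoxyphenyl, so no measured step covers the chain. No change beyond the scatter is therefore expected, and the estimated step is a 1.2-fold lower number from compound 2 to compound 3 (0.08 log units; within the scatter). Compound 3 is estimated at 1500 nM, with an expected range of 600 nM to 4500 nM.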

Compound 3, concentration for 50% growth inhibition: 2100 nM
Compound 3: the middle estimate sits 1.4-fold (0.15 log units) below what was measured; low and high end bracket the measured number.
By their numbers in this assay, from the lowest: compounds 2 and 3 (each within the scatter of the next); then compound 1.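

In this assay, butyl in place of isopropyl on a saturated chain carbon, two bonds along the chain from an aromatic nitrogen, gives a 1.2-fold higher number from compound 2 to compound 3 (0.07 log units; within the scatter). For the compounds shown here, this is the first sign that this part of the chain tolerates a change from isopentyl to hexyl, at least with the 4-chlorophenyl group in place. Nothing available gives a cause for this result. The compounds shown leave open whether an amine or a carboxylic acid at the end of the chain, or a much shorter chain such as ethyl, would hold the number, and whether hexyl behaves alike with the 2,4-dimethoxyphenyl group.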